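Dichlorophenyl replaces aminophenyl on a pyrazolyl enone

The compounds below may be only part of what the source reports. "The series", "measured", "known", "first", "only" and "open" are said of these compounds alone.

Compound 1 `COc1cc(-c2cc(/C=C/C(=O)c3ccc(N)cc3)[nH]n2)cc(OC)c1OC` is measured in a functional assay on SK-OV-3 cells (Homo sapiens) for cytotoxicity, read by sulforhodamine B assay, with a stated time of 48 h, tested at 100 uM (on this read-out lower numbers stand for a stronger effect and higher numbers for a weaker effect at the one concentration tested), and gives -98%, the lowest of the two numbers recorded; compound 2 `COc1ccc(-c2cc(/C=C/C(=O)c3ccc(OC)c(OC)c3)[nH]n2)cc1` gives -95%, within the scatter of compound 1. Compound 3 `COc1cc(-c2cc(/C=C/C(=O)c3ccc(Cl)c(Cl)c3)[nH]n2)cc(OC)c1OC` has not been measured. It differs from compound 1 by 3,4-dichlorophenyl in place of 4-aminophenyl on a carbonyl carbon. Within the data shown here, no step between measured compounds is available as a guide, so only a modest move toward higher numbers, or none beyond the scatter, is expected from compound 1 to compound 3, namely a number 13 percentage points higher from compound 1 to compound 3 (beyond the scatter). In this assay compound 3 is therefore estimated at -85%, with a range from -100% to -50%.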

Compound 3, a percentage reported as activity, at one concentration (the size of the read-out at that concentration, not a potency): -70%
The estimate for compound 3 lay 15 percentage points below the measured number; low and high end bracket the measured number.
By their numbers in this assay, from the lowest: compounds 1 and 2 (each within the scatter of the next); then compound 3.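

In this assay, the group on this carbonyl carbon proves able to shift the read-out: 3,4-dichlorophenyl in place of 4-aminophenyl gives a number 28 percentage points higher from compound 1 to compound 3 (beyond the scatter). The change weakens the effect at the one concentration tested, yet compound 3 still reads -70%, so the 3,4-dichlorophenyl group does not abolish it. Nothing at hand explains this step.

The compounds shown do not separate the loss of the amine from the gain of the two chlorines. On these data alone, how an unsubstituted phenyl, a monochlorophenyl or a hydroxyphenyl would read at this position remains open.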